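A few compounds are considered here, and "the series" means these few. Any claim that something is new, unique, unknown or untested is made for them only; others in the source may bear on it.

Measured so far in a functional assay on MGC-803 cells (Homo sapiens) for inhibition, read by MTT assay, with a stated time of 48 h; a higher number here means a weaker inhibitor, a lower number a stronger inhibitor:

- Compound 1 `COc1ccc(CN(C(C)=O)c2cc(OC)c(OC)c(OC)c2)cc1O` gives 79 nM
- Compound 2 `C#CC(=O)N(Cc1ccc(OC)c(O)c1)c1cc(OC)c(OC)c(OC)c1` gives 170 nM
- Compound 3 `C/C=C/C=C/C(=O)N(Cc1ccc(OC)c(O)c1)c1cc(OC)c(OC)c(OC)c1` gives 140 nM

Compound 3 lies within the usual scatter of both other compounds, so its number cannot be ranked against either. Compound 4 `CCC/C=C/C(=O)N(Cc1ccc(OC)c(O)c1)c1cc(OC)c(OC)c(OC)c1` is compound 3 with one change: propyl in place of prop-1-en-1-yl on a double-bonded chain carbon bound to a double-bonded chain carbon. Among the measured compounds shown here, no measured pair makes this exact change. The nearest evidence is the swapping of groups on the carbonyl carbon: a 1.8-fold higher number from compound 1 to compound 3 (0.25 log units; within the scatter) and a 1.2-fold lower number from compound 2 to compound 3 (0.08 log units; within the scatter), with a 2.2-fold higher number from compound 1 to compound 2 (0.33 log units; beyond the scatter) as the largest step. All three are small, so no step beyond the scatter is expected in this assay. The expected step is a 1.1-fold lower number from compound 3 to compound 4 (0.03 log units; within the scatter) and carries no firm direction. Compound 4 is estimated at 130 nM, with an expected range of 65 nM to 280 nM.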

Compound 4, half-maximal inhibitory concentration: 70 nM
For compound 4 the middle estimate is 1.9-fold (0.27 log units) above the measured one, within the range that was stated.
By their numbers in this assay, from the lowest: compounds 4, 1, 3 and 2 (each within the scatter of the next, the first and the last beyond it).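

In this assay, propyl in place of prop-1-en-1-yl removes one double bond from the chain and stays within the usual scatter (a 2.0-fold lower number from compound 3 to compound 4 (0.30 log units; within the scatter)), so activity here does not depend on that double bond. The pent-1-en-1-yl chain on the carbonyl carbon clearly separates from ethynyl (a 2.4-fold lower number from compound 2 to compound 4 (0.39 log units; beyond the scatter)) but not from methyl (a 1.1-fold lower number from compound 1 to compound 4 (0.05 log units; within the scatter)), so a short and a longer group both fit at this place. No accompanying evidence explains these numbers. As far as these compounds go, whether a longer saturated chain, a phenyl ring or an amine on this chain would keep this level remains open.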